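The source may hold more compounds than are shown below. What is called first, only, known or untested is meant among the compounds shown, and "the series" means these compounds.

Of the compounds shown here, three built on a shared core have been measured in an in vitro ADME assay on microsomes from liver (Homo sapiens) for metabolic stability; on this read-out higher numbers stand for fast clearance and lower numbers for slow clearance. Compound 1 `COc1ccc(-c2cc(-c3cccc(S(C)(=O)=O)c3)cnc2N)cn1` gives 7.6 mL.min-1.g-1 in this assay. Compound 2 `COc1ccc(-c2cc(-c3ccc(S(=O)(=O)NC4CC4)cc3)cnc2N)cn1` gives 15 mL.min-1.g-1 in this assay, a number that lies within the usual scatter of the value of compound 1, so the two cannot be told apart on the numbers shown. For compound 3 `COc1ccc(-c2cc(-c3ccc(S(C)(=O)=O)c(F)c3)cnc2N)cn1` this assay reports only a limit, < 7 mL.min-1.g-1. A fourth member, compound 4 `COc1ccc(-c2cc(-c3ccc(-n4cccn4)cc3)cnc2N)cn1`, has not yet been measured in this assay. It differs from compound 2 by 1H-pyrazol-1-yl in place of cyclopropylsulfamoyl on an aromatic carbon. No measured pair among these compounds shares this change, so there is no precedent in the numbers shown on which to rest a firm expectation. The step of a 1.2-fold higher number from compound 2 to compound 4 (0.08 log units; within the scatter) is nonetheless expected to be modest, leaning toward faster clearance, but not clearly beyond the scatter. On that basis compound 4 is estimated at 18 mL.min-1.g-1 in this assay, with a range from 7 mL.min-1.g-1 to 45 mL.min-1.g-1.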

Compound 4, intrinsic clearance in microsomes: 9 mL.min-1.g-1
Compound 4: the middle estimate sits 2.0-fold (0.30 log units) above what was measured; the range from low to high includes it.
By their numbers in this assay, from the lowest: compounds 1, 4 and 2 (each within the scatter of the next). At a limit, below all of these: compound 3.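

In this assay, 1H-pyrazol-1-yl in place of cyclopropylsulfamoyl on an aromatic carbon, para to a large group, gives a 1.7-fold lower number from compound 2 to compound 4 (0.22 log units; within the scatter). Within the data shown here, all three earlier compounds carry sulfur on this aryl ring, so only this pair shows that a group without sulfur and without a hydrogen-bond donor can stand here and leave the two compounds inseparable on this read-out. Compound 3 is reported only as a limit: the limit of < 7 mL.min-1.g-1 in this assay, at which 1 of the 4 values shown sits.

One step cannot say whether any group at this position would move the read-out beyond the scatter. As far as these compounds go, it remains open whether an amine, a carboxylic acid or a morpholine ring here would read differently in this assay, or whether a pyrazole attached through a carbon atom would match 1H-pyrazol-1-yl.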